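From Compound 3 to Compound 4: A Benzyl Swap

The source may hold more compounds than are shown below. What is called first, only, known or untested is meant among the compounds shown, and "the series" means these compounds.

Three compounds sharing one core, differing only in the aromatic group on a saturated chain carbon bound to a sulfur, have been tested in a functional assay on BGC-823 cells (Homo sapiens) for antiproliferative activity, read by MTT assay, with a stated time of 24 h; on this read-out lower numbers stand for stronger inhibition and higher numbers for weaker inhibition. Here compound 1 (`O=[N+]([O-])c1ccc(CSc2nnc(-c3ccc4c(c3)OCCO4)n2-c2ccccc2)cc1`) gives 48600 nM. Compound 2 (`Clc1cccc(CSc2nnc(-c3ccc4c(c3)OCCO4)n2-c2ccccc2)c1`) gives 51200 nM. Compound 3 (`Cc1ccc(CSc2nnc(-c3ccc4c(c3)OCCO4)n2-c2ccccc2)cc1`) gives 44300 nM. Compound 3 cannot be separated from the other two, with a 1.1-fold lower number from compound 1 to compound 3 (0.04 log units; within the scatter) and a 1.2-fold lower number from compound 2 to compound 3 (0.06 log units; within the scatter).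

The next compound, compound 4 (`Fc1ccccc1CSc1nnc(-c2ccc3c(c2)OCCO3)n1-c1ccccc1`), has not yet been measured. Its difference from compound 3 is 2-fluorophenyl in place of 4-methylphenyl on a saturated chain carbon bound to a sulfur. The most relevant evidence is the set of swaps at this same place, namely a 1.2-fold lower number from compound 2 to compound 3 (0.06 log units; within the scatter) and a 1.1-fold higher number from compound 1 to compound 2 (0.02 log units; within the scatter). Among the compounds with values here, neither moves the number beyond the scatter, although no measured compound carries a 2-fluorophenyl group, so this evidence is indirect. No step beyond the scatter is therefore expected in this assay, and the estimate amounts to a 1.1-fold lower number from compound 3 to compound 4 (0.04 log units; within the scatter). The expected value for compound 4 is 40000 nM, with an estimated range from 15000 nM to 70000 nM.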

Compound 4, half-maximal inhibitory concentration: 18600 nM
Compound 4: middle estimate off by 2.2-fold (0.33 log units), on the high side; measured number inside the range.
By their numbers in this assay, from the lowest: compound 4; then compounds 3, 1 and 2 (each within the scatter of the next).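

Up to this point, swaps at this position in this assay had stayed within the scatter, so the group on the saturated chain carbon bound to a sulfur could have seemed to matter little. The 2-fluorophenyl group changes that picture, giving a 2.4-fold lower number from compound 3 to compound 4 (0.38 log units; beyond the scatter) and, against the other two groups, a 2.8-fold lower number from compound 2 to compound 4 (0.44 log units; beyond the scatter) and a 2.6-fold lower number from compound 1 to compound 4 (0.42 log units; beyond the scatter); all three steps are modest but beyond the scatter, which makes compound 4 the most potent of the four, although compound 4 still gives 18600 nM and so remains in the same broad range as the others. Nothing available explains why this one group separates from the other three.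

Within the data shown here, with only one fluorine-bearing compound, the shift cannot be assigned to the fluorine itself, to its place on the ring or to the loss of the groups it replaces, as 4-methylphenyl, 3-chlorophenyl and 4-nitrophenyl all differ from 2-fluorophenyl in both substituent and substitution pattern. On these data alone, it also remains open how this position would respond to an amine or a carboxylic acid on the phenyl ring, or to a longer chain in place of the saturated chain carbon bound to a sulfur.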